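Aryl variation on the ethylidene arm: toward a chloro-cyano analogue

This account rests on a few compounds, and the source may have more. Where it says the series, first, only, none or still open, it means among the compounds named here.

Measured so far in a functional assay on MCF7 cells (Homo sapiens) for inhibition; on this read-out higher numbers stand for weaker inhibition and lower numbers for stronger inhibition:
- Compound 1, `CC/C(=C(/c1ccc(/C=C/C(=O)O)cc1)c1cc2ccccc2[nH]1)c1ccccc1OC(F)(F)F`: 206 nM
- Compound 2, `CC/C(=C(/c1ccc(/C=C/C(=O)O)cc1)c1cc2ccccc2[nH]1)c1cccc(C(F)(F)F)c1`: 325 nM
- Compound 3, `CC/C(=C(/c1ccc(/C=C/C(=O)O)cc1)c1cc2ccccc2[nH]1)c1cccc(OC(F)(F)F)c1`: 282 nM

Compound 2 carries the highest of the three numbers, yet it is within the scatter of both neighbours: the step of a 1.6-fold higher number from compound 1 to compound 2 (0.20 log units; within the scatter) and the step of a 1.2-fold lower number from compound 2 to compound 3 (0.06 log units; within the scatter) are both too small to rank. The third comparison, a 1.4-fold higher number from compound 1 to compound 3 (0.14 log units; within the scatter), is likewise within the scatter. All three changes swap one fluorinated aryl group for another on the same chain carbon, and none of them moves this assay.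

Compound 4, `CC/C(=C(/c1ccc(/C=C/C(=O)O)cc1)c1cc2ccccc2[nH]1)c1ccc(C#N)cc1Cl`, is not yet measured. It differs from compound 2 by 2-chloro-4-cyanophenyl in place of 3-(trifluoromethyl)phenyl on a double-bonded chain carbon bound to a double-bonded chain carbon and a saturated chain carbon. Going by the values given here, no measured step covers a nitrile or a chlorine on this ring; the only precedent is that three aryl variants at this position gave numbers within the scatter of one another. On that basis the step from compound 2 to compound 4 is expected to be small, a 1.1-fold lower number from compound 2 to compound 4 (0.03 log units; within the scatter), with no confident direction, and compound 4 is estimated at 300 nM, within a range of 90 nM to 1000 nM.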

Compound 4, half-maximal inhibitory concentration: 49 nM
The estimate for compound 4 lay 6.1-fold (0.79 log units) above the measured number; the whole stated range lies above it.
By their numbers in this assay, from the lowest: compound 4; then compounds 1, 3 and 2 (each within the scatter of the next).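

This position on the double-bonded chain carbon is not as flat in this assay as the fluorinated aryl groups suggested: with 2-chloro-4-cyanophenyl the series shows a 6.6-fold lower number from compound 2 to compound 4 (0.82 log units; beyond the scatter) and a 5.8-fold lower number from compound 3 to compound 4 (0.76 log units; beyond the scatter) and a 4.2-fold lower number from compound 1 to compound 4 (0.62 log units; beyond the scatter) and all three steps lie beyond the scatter. The aryl group here can therefore move this read-out, which the three earlier compounds, all within the scatter of one another, did not show. No measured evidence bears on the reason for these steps.

The change brings in a chlorine and a nitrile together, so the compounds shown do not tell which of the two carries the step, or whether both are needed. Also open, going by these compounds, is whether a primary amide or a methoxy group in place of the nitrile would keep the lower number.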